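The source may hold more compounds than are shown below. What is called first, only, known or untested is meant among the compounds shown, and "the series" means these compounds.

Measured compounds:
compound 1 `Cc1cc(-c2c(F)cc3c(=O)c(Cc4cc(O)ccc4O)cn(C4CC4)c3c2F)cc(C)n1` — 360 nM
compound 2 `Cc1cc(-c2c(F)cc3c(=O)c(Cc4ccccc4N)cn(C4CC4)c3c2F)cc(C)n1` — 2100 nM

In a functional assay on P388 cells (Mus musculus) for cytotoxicity (a lower number here means a stronger inhibitor, a higher number a weaker inhibitor), compound 1 gives 360 nM, and compound 2 gives 2100 nM. Among the measured compounds shown here, compound 2 thus stands at the higher of the two numbers, and its only neighbour is compound 1; the step of a 5.8-fold higher number from compound 1 to compound 2 (0.77 log units; beyond the scatter) separates them, with 2-aminophenyl in place of 2,5-dihydroxyphenyl on a saturated chain carbon bound to an aromatic carbon.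

Compound 3 `Cc1cc(-c2c(F)cc3c(=O)c(Cc4ccc(Cl)cc4)cn(C4CC4)c3c2F)cc(C)n1` has not yet been measured. It differs from compound 2 by 4-chlorophenyl in place of 2-aminophenyl on a saturated chain carbon bound to an aromatic carbon. For the measured compounds named here, no measured step covers this exact exchange. Going by the values given here, the one step that does touch the same place, a 5.8-fold higher number from compound 1 to compound 2 (0.77 log units; beyond the scatter), shows that a change of the aromatic group on that saturated chain carbon can move the number beyond the scatter, but it gives no direction for a 4-chlorophenyl. Compound 3 is therefore expected to land close to compound 2, with a step of a 1.2-fold lower number from compound 2 to compound 3 (0.07 log units; within the scatter) that may well fall within the scatter, though a wide range is kept. Compound 3 is estimated at 1800 nM, between 400 nM and 7000 nM in this assay.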

Compound 3, half-maximal inhibitory concentration: 20000 nM
Compound 3: the middle estimate sits 11-fold (1.05 log units) below what was measured; measured number above the stated range.
By their numbers in this assay, from the lowest: compound 1; then compound 2; then compound 3.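

In this assay the group on the saturated chain carbon now shows a direction as well as a reach: the exchange of 2-aminophenyl for 4-chlorophenyl gives a 9.5-fold higher number from compound 2 to compound 3 (0.98 log units; beyond the scatter) even though both groups have 7 heavy atoms and one six-membered aromatic ring of carbon only. Set against the 2,5-dihydroxyphenyl group, the same place spans a 56-fold higher number from compound 1 to compound 3 (1.74 log units; beyond the scatter) and so carries a much wider range than the first step alone could show. Nothing given here accounts for this rise, and the loss of the hydrogen-bond donor and acceptor that 2-aminophenyl has, against 0 of each in 4-chlorophenyl, remains only a difference in counts.

Because 2-aminophenyl and 4-chlorophenyl differ in both the substituent and its ring position, the compounds shown cannot separate the two, a question that 2-chlorophenyl or 4-aminophenyl would address. They also leave open how an unsubstituted phenyl or a single hydroxyl group on the ring would read, and thus whether the higher number comes with the chlorine itself or simply with the absence of the amine and hydroxyl groups.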